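Swapped Double Bond on a Baseline of Limits

The source may report more compounds than this note shows. Statements on the series, on what has been measured and on what is new or still open speak of the compounds shown alone.

Compound 1, `COc1cccc(NC(=O)N[C@@H]2C3CCN(CC3)[C@@H]2Cc2cccnc2)c1`: in an assay on a protein complex for binding affinity to Neuronal acetylcholine receptor; alpha4/beta2 (Homo sapiens) (a lower number here means a stronger inhibitor, a higher number a weaker inhibitor), compound 1 gives > 10000 nM, which is a limit of the assay.
Compound 2, `O=C(Nc1ccc(Cl)c(Cl)c1)N[C@@H]1C2CCN(CC2)[C@@H]1Cc1cccnc1`: in this assay compound 2 gives > 10000 nM, also a limit.
Compound 3, `C/C(=C\c1ccccc1)C(=O)N[C@@H]1C2CCN(CC2)[C@@H]1Cc1cccnc1`: in this assay compound 3 gives > 10000 nM, again a limit.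

Going by the values given here, compound 3 therefore stands nowhere readable on a scale: it shares (the limit of > 10000 nM in this assay, at which 3 of the 3 values shown sit), so no compound among the three is set apart from another. The measured steps all connect limits, and so a step that the two limits leave unreadable from compound 1 to compound 2, a step that the two limits leave unreadable from compound 1 to compound 3 and a step that the two limits leave unreadable from compound 2 to compound 3 give no size and no direction.

Compound 4, `C/C(=C\C(=O)N[C@@H]1C2CCN(CC2)[C@@H]1Cc1cccnc1)c1ccccc1`, keeps every atom of compound 3 and rearranges one group: 2-phenylprop-1-en-1-yl in place of 1-methyl-2-phenylethenyl on a carbonyl carbon. Among the compounds with values here, none of the measured steps can be read, so none speaks for a move in either direction. Because (the limit of > 10000 nM in this assay, at which 3 of the 3 values shown sit), compound 4 is expected to remain at the limit as well, and the step that the limit leaves unreadable from compound 3 to compound 4 is expected to show nothing beyond the scatter. The estimate for compound 4 is 20000 nM, with a range from 5000 nM to 100000 nM.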

Compound 4, inhibition constant: > 10000 nM
Compound 4: only a limit was reported; the forecaster's own chance of this, stated with the estimate: 85%; the middle value is on the limit's open side.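

The steps from compound 1, compound 2 and compound 3 to compound 4 cannot be read, because each joins two limits: the limit of > 10000 nM in this assay, at which 4 of the 4 values shown sit.

The compounds shown leave open how strongly any of them binds, and whether any group on the carbonyl carbon would give a readable value.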